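Chloro in Place of Methoxy: Effect on Solubility

The source may hold more compounds than are shown below. What is called first, only, known or untested is meant among the compounds shown, and "the series" means these compounds.

Compound 1 `COc1ccc2c(=O)c(Cc3ccccc3)c(C)[nH]c2c1` and compound 3 `COc1ccc2c(c1)c(=O)c(Cc1ccccc1)c(C)n2C` are built on closely related cores, though the difference between the two cores is not broken down here. In a physicochemical assay for solubility, read by HPLC, at pH 7.4 (on this read-out higher numbers stand for higher solubility and lower numbers for lower solubility), compound 1 gives 5000 nM. In this assay compound 3 gives 10000 nM, a number that lies within the usual scatter of the value of compound 1, so no order between the two can be drawn.

Compound 2 `Cc1[nH]c2cc(Cl)ccc2c(=O)c1Cc1ccccc1` differs from compound 1 by chloro in place of methoxy on an aromatic carbon. In this assay compound 2 returns only a limit of the assay, < 2000 nM. This yields the step of an at least 2.5-fold lower number from compound 1 to compound 2 (0.39 log units; beyond the scatter), which rests on (the limit of < 2000 nM in this assay, at which 1 of the 3 values shown sits).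

Compound 4 `Cc1c(Cc2ccccc2)c(=O)c2cc(Cl)ccc2n1C` has not yet been measured. It differs from compound 3 by chloro in place of methoxy on an aromatic carbon. The place is described in exactly the same words as for the earlier pair, so this is the same change made a second time, on the core of compound 3 rather than that of compound 1.

Carrying the measured step across, compound 4 is expected to fall below compound 3 by a 3.3-fold lower number from compound 3 to compound 4 (0.52 log units; beyond the scatter) in this assay. This expectation rests on the step of an at least 2.5-fold lower number from compound 1 to compound 2 (0.39 log units; beyond the scatter) and nothing more. Because compound 2 gave < 2000 nM, a limit, compound 4 may likewise return only a limit. The estimate for compound 4 in this assay is 3000 nM, expected to lie between 1200 nM and 7000 nM.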

Compound 4, solubility: 2000 nM
Compound 4: middle estimate off by 1.5-fold (0.18 log units), on the high side; the range from low to high includes it.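

Chloro in place of methoxy on an aromatic carbon gives a 5.0-fold lower number from compound 3 to compound 4 (0.70 log units; beyond the scatter) in this assay, and the same change on the other core gave an at least 2.5-fold lower number from compound 1 to compound 2 (0.39 log units; beyond the scatter), so the direction of the step carries over between the two cores shown. The newer step has a definite size, whereas the earlier one is only a bound, which means the two sizes cannot be set against each other: the limit of < 2000 nM in this assay, at which 1 of the 4 values shown sits. Two pairs on two closely related cores make no rule for other cores, and they do not tell why the number falls.

At this aromatic carbon the compounds shown carry only methoxy and chloro, so it stays open how an amine, a carboxylic acid or a longer chain such as ethoxy would read in this assay. What the difference between the two cores does on its own also stays open, as no pair shown isolates it.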